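Methyl on the benzyl ring of compound 3

The compounds below may be only part of what the source reports. "The series", "measured", "known", "first", "only" and "open" are said of these compounds alone.

Of the compounds shown here, three have been measured in an assay for inhibition of Amine oxidase [flavin-containing] A (Rattus norvegicus); a lower number here means a stronger inhibitor, a higher number a weaker inhibitor. Compound 1 `Cc1ccc(COc2ccc(-c3nn(CCC#N)c(=O)o3)cc2)cc1` gives 25000 nM in this assay. Compound 2 `COc1ccc(COc2ccc(-c3nn(CCC#N)c(=S)o3)cc2)cc1` gives 4800 nM. Compound 3 `N#CCCN1N=C(c2ccc(OCc3ccccc3)cc2)OCC1=O`, whose core differs from the other two, gives 160000 nM, the highest of the three numbers; its nearest neighbour is compound 1, at a number lower by a margin beyond the usual scatter, and its furthest is compound 2, lower by a wider margin still.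

Compound 4 `Cc1ccc(COc2ccc(C3=NN(CCC#N)C(=O)CO3)cc2)cc1` has not yet been measured. It differs from compound 3 by methyl in place of hydrogen on an aromatic carbon of a six-membered aromatic ring of carbon only, so that benzyl becomes 4-methylbenzyl. Going by the values given here, no pair among the measured compounds isolates this change, since compound 1 carries the same methyl but on a different core, so the size of its effect cannot be read from the data directly.

On that basis compound 4 is expected to sit near compound 3, with a step of a 2.0-fold lower number from compound 3 to compound 4 (0.30 log units; within the scatter) that is at most modest and more likely toward a lower number than a higher one. The estimate for compound 4 is 80000 nM, within a range from 30000 nM to 220000 nM.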

Compound 4, half-maximal inhibitory concentration: 250000 nM
Beside the measured number, compound 4's estimate is 3.1-fold (0.49 log units) below it; measured number above the stated range.
By their numbers in this assay, from the lowest: compound 2; then compound 1; then compounds 3 and 4 (each within the scatter of the next).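

In this assay, going by these compounds alone, this is the first pair that isolates the change from benzyl to 4-methylbenzyl, and it shows a 1.6-fold higher number from compound 3 to compound 4 (0.19 log units; within the scatter) and so no separation between the two compounds. On this core, then, methyl in place of hydrogen on an aromatic carbon, para to a large group, is accommodated without any shift beyond the scatter, and the added carbon brings no lowering of the number that can be told apart from repeat measurement. Nothing available bears on why the number stays put at this position.

The compounds shown leave open whether a group other than methyl at this place, such as an amine or a carboxylic acid, would move the number on this core beyond the scatter. They also leave open whether the same methyl change would read alike on the core of compound 1, which has no partner here carrying plain benzyl on that core.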